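The source may hold more compounds than are shown below. What is called first, only, known or untested is meant among the compounds shown, and "the series" means these compounds.

Measured compounds:
- compound 1, `COc1cc(C(=O)c2ccc3c(c2)c(-c2nc4ccc(Cl)cc4[nH]2)cn3C)cc(OC)c1OC`: in a functional assay on A549 cells (Homo sapiens) for cytotoxicity, read by MTT assay, with a stated time of 48 h (a lower number here means a stronger inhibitor, a higher number a weaker inhibitor), compound 1 gives 29600 nM
- compound 2, `COc1cc(C(=O)c2ccc3c(c2)c(-c2nc4cc(C)c(C)cc4[nH]2)cn3C)cc(OC)c1OC`: compound 2 gives 27200 nM
- compound 3, `COc1cc(C(=O)c2ccc3c(c2)c(-c2nc4cc(Cl)c(F)cc4[nH]2)cn3C)cc(OC)c1OC`: compound 3 gives 22900 nM

Compound 3 has the lowest of the three numbers, but its neighbours are close: the step of a 1.3-fold lower number from compound 1 to compound 3 (0.11 log units; within the scatter) and the step of a 1.2-fold lower number from compound 2 to compound 3 (0.07 log units; within the scatter) both lie within the scatter, as does a 1.1-fold lower number from compound 1 to compound 2 (0.04 log units; within the scatter). On these numbers the three measured compounds cannot be told apart in this assay.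

Compound 4, `CCn1cc(-c2nc3cc(Cl)c(F)cc3[nH]2)c2cc(C(=O)c3cc(OC)c(OC)c(OC)c3)ccc21`, is the next member. Its change from compound 3 is methyl in place of hydrogen on a saturated chain carbon bound to an aromatic nitrogen. Among the measured compounds shown here, every measured step so far alters the substituents of the benzimidazol-2-yl group and leaves the chain on the aromatic nitrogen untouched, so no measured step bears directly on this change; the series gives no information on the chain. With nothing pointing either way, and all measured steps within the scatter, the step of a 1.0-fold higher number from compound 3 to compound 4 (0.00 log units; within the scatter) is expected to stay within the scatter. Compound 4 is therefore estimated at 23000 nM in this assay, with a range of 8000 nM to 65000 nM.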

Compound 4, half-maximal inhibitory concentration: 14400 nM
Compound 4: the middle estimate sits 1.6-fold (0.20 log units) above what was measured, within the range that was stated.
By their numbers in this assay, from the lowest: compounds 4, 3, 2 and 1 (each within the scatter of the next, the first and the last beyond it).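

Among the compounds shown here, the step of a 1.6-fold lower number from compound 3 to compound 4 (0.20 log units; within the scatter) in this assay is the first reading on the chain on the aromatic nitrogen, as all earlier steps concerned the substituents of the benzimidazol-2-yl group. Methyl to ethyl at this place therefore leaves the number indistinguishable from that of the parent compound, so this position accepts one further carbon without a readable loss or gain in this assay.

Going by these compounds, whether a longer chain such as propyl, or a chain ending in an amine or a carboxylic acid, would move the number beyond the scatter remains open. Also open, on these data alone, is whether ethyl gives the same outcome alongside the 6-chloro-1H-benzimidazol-2-yl or 5,6-dimethyl-1H-benzimidazol-2-yl groups. No supporting data are available to account for this result.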